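Sulfone series at the glutamate receptor: the step to compound 4

A few compounds are considered here, and "the series" means these few. Any claim that something is new, unique, unknown or untested is made for them only; others in the source may bear on it.

Measured so far in an assay on isolated protein for displacement of a labelled ligand from metabotropic glutamate receptor 5 (Homo sapiens), with a stated time of 60 min, tested at 1 uM; on this read-out higher numbers stand for more inhibition at the one concentration tested (going by the name of the read-out) and lower numbers for less inhibition:
compound 1 `CC1CCN(c2c(S(=O)(=O)c3ccccc3)cnc3ccccc23)CC1` gives 89.2%
compound 2 `Cc1ccc(S(=O)(=O)c2cnc3cc(F)ccc3c2N2CCC(C)CC2)cc1C` gives 90%
compound 3 `Cc1ccc(S(=O)(=O)c2cnc3ccc(Cl)cc3c2N2CCC(C)CC2)cc1F` gives 68%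

Compound 2 and compound 1 lie within the usual scatter of each other, so nothing separates them on these numbers. Compound 3 sits beyond the scatter under compound 2, but it differs from compound 2 in more than one place, so what the two values show cannot be tied to a single change.

Compound 4 `COc1ccc(S(=O)(=O)c2cnc3cc(F)ccc3c2N2CCC(C)CC2)cc1OC` has not been measured. Compared with compound 2 the change is 3,4-dimethoxyphenyl in place of 3,4-dimethylphenyl on a sulfonyl sulfur. For the measured compounds named here, no measured pair isolates a change of this kind on the sulfonyl sulfur, so there is no step to lean on.

Without such a step, the expectation for this assay is a step from compound 2 to compound 4 of about a number 10 percentage points lower from compound 2 to compound 4 (within the scatter), a modest drop that may not clear the scatter. Compound 4 is therefore estimated at 80%, with a range from 60% to 95%.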

Compound 4, a percentage reported as inhibition, at one concentration (the size of the read-out at that concentration, not a potency): 83%
For compound 4 the middle estimate is 3 percentage points below the measured one; the measured number falls inside the stated range.
By their numbers in this assay, from the lowest: compound 3; then compounds 4, 1 and 2 (each within the scatter of the next).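

In this assay, for the compounds shown here, the pair compound 2 and compound 4 is the first to isolate a change on the sulfonyl sulfur, and it gives a number 7 percentage points lower from compound 2 to compound 4 (within the scatter). On this read-out, 3,4-dimethoxyphenyl and 3,4-dimethylphenyl cannot be told apart at this position, so the hydrogen-bond acceptors that enter with the dimethoxy group do not separate compound 4 from compound 2. No measurement at hand bears on why the two groups read alike.

From the compounds shown here alone, a percentage at one concentration is not a potency, so any difference in potency between compound 2 and compound 4 remains open. Also open, going by these compounds, is how the read-out responds to a carboxylic acid or an amine on the aromatic ring attached to the sulfonyl sulfur.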